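Swapping a dimethylphenyl for a phenylpropyl on the ring nitrogen

The compounds below may be only part of what the source reports. "The series", "measured", "known", "first", "only" and "open" are said of these compounds alone.

Three related compounds have been tested in a toxicity assay on L3.6pl cells (Homo sapiens) for inhibition, read by ATP content, with a stated time of 72 h; on this read-out lower numbers stand for stronger inhibition and higher numbers for weaker inhibition. Compound 1, `COc1ccccc1C(=O)Nc1ccc(N2CCN(c3cccc(C)c3C)CC2)cc1C(=O)O`, gives 22900 nM in this assay. That is the lower of the two numbers recorded, and it sits beyond the usual scatter from compound 2, `COc1ccc(C(=O)Nc2ccc(N3CCN(c4cc(Cl)ccc4C)CC3)cc2C(=O)O)c(OC)c1`, which gives 61600 nM in this assay. Compound 3, `COc1ccccc1C(=O)Nc1ccc(CN2CCN(c3ccccn3)CC2)cc1C(=O)O`, is reported in this assay only as a limit, > 10000 nM, and not as a number.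

Compound 4, `COc1ccccc1C(=O)Nc1ccc(N2CCN(CCCc3ccccc3)CC2)cc1C(=O)O`, has not yet been measured. It differs from compound 1 in one place: 3-phenylpropyl in place of 2,3-dimethylphenyl on an amine nitrogen in a ring. Going by the values given here, no measured pair of compounds in this set differs in exactly one place, so there is no direct precedent for the size of such a step. The change keeps the rest of compound 1 intact, and a step of a 1.3-fold higher number from compound 1 to compound 4 (0.12 log units; within the scatter) is expected, lying within the scatter or slightly weaker. Compound 4 is therefore estimated at 30000 nM in this assay, with a plausible range from 8000 nM to 100000 nM.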

Compound 4, half-maximal inhibitory concentration: > 10000 nM
Compound 4 gave a limit, no number; the forecaster's own chance of this, stated with the estimate: 25%; the middle value lies beyond the limit too.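

Going by these compounds alone, compound 4 gives only a limit in this assay, > 10000 nM, so no step from compound 1 to compound 4 can be read. Still open is whether 3-phenylpropyl in place of 2,3-dimethylphenyl changes the number at all, and how far compound 3 and compound 4 lie past the shared limit: the limit of > 10000 nM in this assay, at which 2 of the 4 values shown sit.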